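Substituent change ortho to methylsulfonyl on the acylguanidine core

The compounds below may be only part of what the source reports. "The series", "measured", "known", "first", "only" and "open" are said of these compounds alone.

The series holds the shared core of compound 1 `CS(=O)(=O)c1cc(C(=O)N=C(N)N)ccc1C#N` with a varied substituent ortho to the methylsulfonyl group. In a functional assay for inhibition of sodium/hydrogen exchanger (Oryctolagus cuniculus) (a lower number here means a stronger inhibitor, a higher number a weaker inhibitor), compound 1 gives 140 nM. Compound 2 `CS(=O)(=O)c1cc(C(=O)N=C(N)N)ccc1C1CCCCC1` gives 340 nM, and compound 3 `CS(=O)(=O)c1cc(C(=O)N=C(N)N)ccc1Oc1cncc(Cl)c1` gives 75 nM. Compound 3 has the lowest number of the three: the step of a 1.9-fold lower number from compound 1 to compound 3 (0.27 log units; within the scatter) stays within the scatter, while the step of a 4.5-fold lower number from compound 2 to compound 3 (0.66 log units; beyond the scatter) lies beyond it, as does a 2.4-fold higher number from compound 1 to compound 2 (0.39 log units; beyond the scatter).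

Compound 4 `CS(=O)(=O)c1cc(C(=O)N=C(N)N)ccc1-n1ccc(=O)cc1` differs from compound 3 by a group of 7 heavy atoms (5 carbon, 1 nitrogen, 1 oxygen; one six-membered aromatic ring with 1 hetero atom) in place of a group of 8 heavy atoms (5 carbon, 1 nitrogen, 1 oxygen, 1 chlorine; one six-membered aromatic ring with 1 hetero atom), on an aromatic carbon. Among the compounds with values here, no measured step swaps one ring-bearing substituent for another at this carbon; the steps that bear on the change all alter the same position, and none of them is large. Both ring-bearing groups measured so far, in compound 2 and compound 3, sit on either side of the cyano compound 1. A step of similar modest size is therefore expected in this assay, most likely toward a higher number or no change beyond the scatter, as a 2.1-fold higher number from compound 3 to compound 4 (0.33 log units; beyond the scatter). Compound 4 is expected at 160 nM, in the range 55 nM to 480 nM.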

Compound 4, half-maximal inhibitory concentration: 710 nM
For compound 4 the middle estimate is 4.4-fold (0.65 log units) below the measured one, outside the stated range (above it).
By their numbers in this assay, from the lowest: compounds 3 and 1 (each within the scatter of the next); then compound 2; then compound 4.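

At this carbon, ortho to a methylsulfonyl group, a six-membered aromatic ring with 1 hetero atom does not in itself fix the number in this assay: a 9.5-fold higher number from compound 3 to compound 4 (0.98 log units; beyond the scatter) is the largest step among the four compounds, although both groups carry such a ring. The group entering in compound 4 also stands apart from the cyclohexyl and cyano groups, with a 2.1-fold higher number from compound 2 to compound 4 (0.32 log units; beyond the scatter) and a 5.1-fold higher number from compound 1 to compound 4 (0.71 log units; beyond the scatter), which gives compound 4 the highest number of the series, with every step to it beyond the scatter. Heavy-atom count does not order the numbers either: the cyano group and the (5-chloropyridin-3-yl)oxy group differ widely in size, yet a 1.9-fold lower number from compound 1 to compound 3 (0.27 log units; within the scatter) stays within the scatter, while the group of 7 heavy atoms lies far from the group of 8.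

No measurement at hand accounts for the size of the step from compound 3 to compound 4. From the compounds shown here alone, how a phenoxy group, or a pyridin-3-yloxy group without its chlorine, would stand in this assay remains open, and so does which part of the exchange carries the step.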